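The source may hold more compounds than are shown below. What is called first, only, known or untested is meant among the compounds shown, and "the series" means these compounds.

Compound 1 `C=CCn1c(SC/C(=N/O)c2ccccc2)nnc1-c1ccc(OC)cc1` gives 67% in a functional assay on the whole organism (strain albino) for inhibition, with Rattus norvegicus as the target, read by paw edema, with a stated time of 3 h, at a dose of 0.28 mmol/kg by the oral route; a lower number here means less inhibition, a higher number more inhibition at the dose given (going by the name of the read-out). Compound 2 `C=CCn1c(SCC(=O)c2ccccc2)nnc1-c1ccc(OC)cc1` gives 63% in this assay. The only step in the series, a number 4 percentage points lower from compound 1 to compound 2 (within the scatter), lies within the scatter, so compound 1 does not stand apart from compound 2 on the numbers shown. Compound 3 `CCn1c(SC/C(=N/O)c2ccccc2)nnc1-c1ccc(OC)cc1` differs from compound 1 by methyl in place of vinyl on a saturated chain carbon bound to an aromatic nitrogen. Going by the values given here, no measured step touches this place; the step of a number 4 percentage points lower from compound 1 to compound 2 (within the scatter) concerns the saturated chain carbon bound to a sulfur and is itself small. No step beyond the scatter is therefore expected, a number 5 percentage points lower from compound 1 to compound 3 (within the scatter). Compound 3 is estimated at 62%, expected between 46% and 78%.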

Compound 3, a percentage reported as inhibition, in the whole organism at one dose (the size of the read-out at that dose, not a potency): 75%
Estimate against measurement, compound 3: 13 percentage points below; low and high end bracket the measured number.
By their numbers in this assay, from the lowest: compounds 2, 1 and 3 (each within the scatter of the next, the first and the last beyond it).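

At the saturated chain carbon bound to an aromatic nitrogen, methyl in place of vinyl, which also reads as allyl to ethyl, gives a number 8 percentage points higher from compound 1 to compound 3 (within the scatter) in this assay. This position, untouched by the earlier step, thus takes the loss of the double bond outside aromatic rings with no step beyond the scatter, though this rests on one pair.

From the compounds shown here alone, whether a longer chain such as butyl, a benzyl group or a chain ending in an amine would hold at this position stays open. Nothing at hand bears on a cause for this step.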